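Hydrazone aryl variation on the shared core: cytotoxicity notes

A few compounds are considered here, and "the series" means these few. Any claim that something is new, unique, unknown or untested is made for them only; others in the source may bear on it.

Three hydrazones on the shared core have been measured in a functional assay on SW 1116 cells (Homo sapiens) for cytotoxicity, read by MTT assay, with a stated time of 48 h; on this read-out higher numbers stand for weaker inhibition and lower numbers for stronger inhibition. Compound 1 `O=C(CSc1nnc(-c2ccncc2)o1)N/N=C/c1ccc(F)cc1` gives 15700 nM. Compound 2 `O=C(CSc1nnc(-c2ccncc2)o1)N/N=C/c1ccc(Cl)cc1` gives 17000 nM. Compound 3 `O=C(CSc1nnc(-c2ccncc2)o1)N/N=C/c1ccccc1F` gives 21500 nM, the highest of the three numbers, though its step from compound 1 (a 1.4-fold higher number from compound 1 to compound 3 (0.14 log units; within the scatter)) and from compound 2 (a 1.3-fold higher number from compound 2 to compound 3 (0.10 log units; within the scatter)) both sit inside the scatter, as does the step of a 1.1-fold higher number from compound 1 to compound 2 (0.03 log units; within the scatter); on these numbers the three compounds are not separated.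

Compound 4 `O=C(CSc1nnc(-c2ccncc2)o1)N/N=C/c1cc(Cl)cc(Cl)c1O` carries the change (3,5-dichloro-2-hydroxyphenyl in place of 2-fluorophenyl on a carbon with a double bond to nitrogen). The measured steps bear on it only loosely: they show that moving a single halogen around the aryl group, or exchanging chloro for fluoro, leaves this assay unmoved beyond the scatter. Within the data shown here, no measured pair tests a hydroxyl or a second chloro on that aryl group, so the series gives no direct guide to the new substitution.

With no step beyond the scatter among the three measured compounds, the expectation for compound 4 is a number close to that of compound 3, with the step of a 1.2-fold lower number from compound 3 to compound 4 (0.08 log units; within the scatter) expected to fall within the scatter. From the compounds shown here alone, compound 4 is therefore estimated at 18000 nM, within a range from 6000 nM to 50000 nM, the range widened because the new aryl group is untested.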

Compound 4, half-maximal inhibitory concentration: 5030 nM
Estimate against measurement, compound 4: 3.6-fold (0.55 log units) above; measured number below the stated range.
By their numbers in this assay, from the lowest: compound 4; then compounds 1, 2 and 3 (each within the scatter of the next).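

Notes on the aryl position: in this assay, the aryl group on a carbon with a double bond to nitrogen is shown for the first time to move the number beyond the scatter, with 3,5-dichloro-2-hydroxyphenyl giving a 4.3-fold lower number from compound 3 to compound 4 (0.63 log units; beyond the scatter) and a 3.4-fold lower number from compound 2 to compound 4 (0.53 log units; beyond the scatter) and a 3.1-fold lower number from compound 1 to compound 4 (0.49 log units; beyond the scatter) in turn. The earlier single-halogen aryl groups stayed within the scatter of one another, so compound 4 is the only one of the four that stands apart from the rest, and although all three of its steps are modest, each points to a lower number. The change brings in a hydroxyl and two chloro groups at once, so the step belongs to the whole 3,5-dichloro-2-hydroxyphenyl group and not to any one of its parts, and nothing available bears on why the number falls.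

The compounds shown leave open whether the hydroxyl alone or the two chloro groups alone would give a step of this size. They also leave open whether a methoxy group or an amine in place of the hydroxyl would keep the lower number.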